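Stilbene ethers with amine tails in the electroshock model

This account rests on a few compounds, and the source may have more. Where it says the series, first, only, none or still open, it means among the compounds named here.

Two compounds of the series carry a stilbene core linked through an oxygen and a four-carbon chain to a tertiary amine. Compound 1 `CCCN(CCC)CCCCOc1ccccc1/C=C/c1ccccc1` gives 0% in a functional assay on the whole organism with Mus musculus as the target, in the maximal electroshock model, at a dose of 50 mg/kg by the oral route (on this read-out lower numbers stand for less inhibition and higher numbers for more inhibition at the one dose given (going by the name of the read-out)), and compound 2 `CN(C)CCCCOc1cccc(/C=C/c2ccccc2)c1` gives 0% in this assay, so the two stand level within the scatter and neither shows inhibition at the dose given. Compound 3 `CCN1CCN(CCCCOc2ccccc2/C=C/c2ccccc2)CC1` has not yet been measured in this assay. It differs from compound 1 in one place: 4-ethylpiperazin-1-yl in place of dipropylamino on a saturated chain carbon, four bonds along the chain from an oxygen on an aromatic ring. Among the compounds with values here, no step between measured compounds is available for this change. Since compound 1 gives 0% and compound 2 likewise shows no inhibition, the expected step of no change at the digits printed from compound 1 to compound 3 (within the scatter) is none beyond the scatter. Compound 3 is therefore estimated at 0%, with a range from 0% to 15%.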

Compound 3, a percentage reported as inhibition, in the whole organism at one dose (the size of the read-out at that dose, not a potency): 33.3%
Estimate against measurement, compound 3: 33.3 percentage points below; measured number above the stated range.
By their numbers in this assay, from the lowest: compounds 1 and 2 (each within the scatter of the next); then compound 3.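

In this assay the exchange of dipropylamino for 4-ethylpiperazin-1-yl on the saturated chain carbon gives a number 33.3 percentage points higher from compound 1 to compound 3 (beyond the scatter) and thus shows that this place in the molecule is not silent. Within the data shown here, the group at the end of the chain can decide whether any inhibition appears at the one dose given, which the earlier compounds, level with each other and without inhibition, could not show. Nothing at hand accounts for the step.

The compounds shown leave open whether the ring alone carries the step or whether its second nitrogen and ethyl group are needed, as a piperidine, a morpholine or a 4-methylpiperazin-1-yl at this place is not among them. They also leave open how the step would look at other doses.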